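The source may report more compounds than this note shows. Statements on the series, on what has been measured and on what is new or still open speak of the compounds shown alone.

Compound 3 `COc1ccc(CS(=O)(=O)/C=C/c2c(OC)cc(OC)cc2OC)cc1` gives 30 nM in a functional assay on H157 cells (Homo sapiens) for antiproliferative activity, read by trypan blue exclusion (on this read-out higher numbers stand for weaker inhibition and lower numbers for stronger inhibition), the lowest of the three numbers recorded so far. Compound 2 `COc1ccc(CS(=O)(=O)/C=C/c2c(OC)cccc2OC)cc1` gives 700 nM and compound 1 `COc1ccc(CS(=O)(=O)/C=C/c2ccc(F)cc2OC)cc1` gives 20000 nM in this assay; both gaps to compound 3 lie beyond the scatter. Among the compounds with values here, the only single-place step measured so far, a 23-fold lower number from compound 2 to compound 3 (1.37 log units; beyond the scatter), arose from methoxy in place of hydrogen on the same aromatic carbon that changes next. Compound 4 `COc1ccc(CS(=O)(=O)/C=C/c2c(OC)cc(F)cc2OC)cc1` differs from compound 3 by fluoro in place of methoxy on an aromatic carbon. Since that carbon carries neither the methoxy of compound 3 nor the hydrogen of compound 2 in compound 4, a number between those two compounds is expected in this assay. The estimate for compound 4 is 200 nM, range 50 nM to 1000 nM, an expected step of a 6.7-fold higher number from compound 3 to compound 4 (0.82 log units; beyond the scatter).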

Compound 4, half-maximal inhibitory concentration: 500 nM
Beside the measured number, compound 4's estimate is 2.5-fold (0.40 log units) below it; low and high end bracket the measured number.
By their numbers in this assay, from the lowest: compound 3; then compounds 4 and 2 (each within the scatter of the next); then compound 1.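

At this carbon, para to a large group, fluoro does not match methoxy in this assay (a 17-fold higher number from compound 3 to compound 4 (1.22 log units; beyond the scatter)). Fluoro in place of hydrogen leaves no difference beyond the scatter (a 1.4-fold lower number from compound 2 to compound 4 (0.15 log units; within the scatter)). Methoxy in place of hydrogen now also has a second reading on another core (a 40-fold lower number from compound 1 to compound 4 (1.60 log units; beyond the scatter)), and the two readings agree in size: the same change on two cores in this assay, a 23-fold lower number (1.37 log units; beyond the scatter) from compound 2 to compound 3 and a 40-fold lower number (1.60 log units; beyond the scatter) from compound 1 to compound 4, 1.7-fold (0.23 log units) apart, within the scatter of two such steps.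

As far as these compounds go, what an amine, a hydroxy group or a longer chain would give on this carbon stays open. So does whether the methoxy step holds in other cell lines.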